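From a tert-butoxycarbonyl group to chlorine

The source may hold more compounds than are shown below. What is called first, only, known or untested is meant among the compounds shown, and "the series" means these compounds.

Three compounds built on one shared core have been examined, and a fourth waits for its measurement. Compound 1 `CCn1c(CNc2ccccc2)nnc1SCC(=O)Nc1ccc(C(C)=O)cc1` carries a different group on its outer aromatic ring; in an assay on isolated protein for inhibition of long-chain fatty acid transport protein 1 (Mus musculus) (on this read-out lower numbers stand for stronger inhibition and higher numbers for weaker inhibition), compound 1 gives "not determined" (no result reported), so no number exists for it. Compound 2 `CCn1c(CNc2ccccc2)nnc1SCC(=O)Nc1ccc(C(=O)NC)cc1` reaches only a limit of the assay: in this assay compound 2 gives > 10000 nM. Compound 3 `CCn1c(CNc2ccccc2)nnc1SCC(=O)Nc1ccc(C(=O)OC(C)(C)C)cc1` likewise stands at a limit, giving > 10000 nM in this assay. Within the data shown here, because both values are limits, the single step between measured compounds, a step that the two limits leave unreadable from compound 2 to compound 3, has no readable size, and the common point is the limit of > 10000 nM in this assay, at which 2 of the 3 values shown sit. Compound 3 therefore stands no higher than any other number shown, and nothing more can be said of its place.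

Compound 4 `CCn1c(CNc2ccccc2)nnc1SCC(=O)Nc1ccc(Cl)cc1` differs from compound 3 in one place: chloro in place of tert-butoxycarbonyl on an aromatic carbon. Among the measured compounds shown here, no measured step bears on this change, since the only step available is unreadable. The two measured analogues give no sign of strong inhibition, so compound 4 is expected to remain weak, with a value estimated at 10000 nM and a range from 2000 nM to 50000 nM. The step implied by that estimate, a number no higher from compound 3 to compound 4 (the limit leaves the size open), is expected to show no change beyond the scatter.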

Compound 4, half-maximal inhibitory concentration: > 10000 nM
Compound 4: a limit, no number (the forecaster's own chance of this, stated with the estimate: 60%); the middle value sits exactly at the limit.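

The steps among compound 2, compound 3 and compound 4 cannot be read, and what these compounds share is a limit of the assay, not a number: the limit of > 10000 nM in this assay, at which 3 of the 4 values shown sit.

The compounds shown leave open how strongly each of the three inhibits in this assay, and whether any group on this aromatic carbon would give a measurable number.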